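A Fluoro Substitution Tried on Two Related Cores

The compounds below may be only part of what the source reports. "The series", "measured", "known", "first", "only" and "open" are said of these compounds alone.

Compound 3 `CNC(=O)c1cc(Oc2ccc(NC(=O)c3cc(-c4ccc(F)cc4)ncn3)cc2)ccn1` and compound 1 `CNC(=O)c1cc(Oc2ccc(NC(=O)c3cc(-c4ccc(F)cc4)ncn3)cc2F)ccn1` share one core and differ in a single place: fluoro in place of hydrogen on an aromatic carbon. In a functional assay on MCF7 cells (Homo sapiens) for cytotoxicity, read by MTT assay, with a stated time of 72 h (on this read-out lower numbers stand for stronger inhibition and higher numbers for weaker inhibition), compound 3 gives only a limit, > 100000 nM. Compound 1 likewise reaches only a limit in this assay, namely > 100000 nM. The step that the two limits leave unreadable from compound 3 to compound 1 therefore cannot be put into a number, because of the limit of > 100000 nM in this assay, at which 2 of the 3 values shown sit.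

Compound 2 `CNC(=O)c1cc(Oc2ccc(NC(=O)c3nccc(-c4ccc(C)cc4)n3)cc2)ccn1` is built on a different core; the difference between the core of compound 2 and the core of compound 3 is not broken down here. In this assay, for the measured compounds named here, compound 2 gives 44300 nM, the only plain number among the three measured compounds, though still a weak one.

Compound 4 `CNC(=O)c1cc(Oc2ccc(NC(=O)c3nccc(-c4ccc(C)cc4)n3)cc2F)ccn1` has not yet been measured. It differs from compound 2 by fluoro in place of hydrogen on an aromatic carbon, which is the same change, at the same place, that separates compound 3 from compound 1. Going by the values given here, the only measured example of this change gave no readable step, since both of its partners sit at the limit, so there is no evidence here that the fluoro makes the compounds stronger or weaker. From compound 2 to compound 4 a step of about a 1.0-fold higher number from compound 2 to compound 4 (0.01 log units; within the scatter) is expected, that is, a change that stays within the usual scatter of this kind of measurement. Compound 4 is accordingly estimated to give about 45000 nM in this assay, with a range of 15000 nM to 130000 nM, and with a real chance that only a limit is reported, as for compound 1 and compound 3.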

Compound 4, half-maximal inhibitory concentration: 69200 nM
For compound 4 the middle estimate is 1.5-fold (0.19 log units) below the measured one, within the range that was stated.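

In this assay, fluoro in place of hydrogen on the core of compound 2 gives a 1.6-fold higher number from compound 2 to compound 4 (0.19 log units; within the scatter), so the two compounds on this core cannot be told apart, and this is the only readable measure of the change in the series. The same change on the other core, from compound 3 to compound 1, cannot be read, because neither compound gives a plain number and any step between them stays hidden: the limit of > 100000 nM in this assay, at which 2 of the 4 values shown sit. The result therefore shows that the fluoro leaves no effect beyond the usual scatter on one core, but it does not show that the change carries over from one core to the other, since a transfer can only be checked when both cores give a readable step.

The compounds shown leave open whether a chloro or a methoxy group on that same aromatic carbon, ortho to the (2-(methylcarbamoyl)pyridin-4-yl)oxy group, would give a step beyond the scatter. They also leave open whether an amine or a carboxylic acid in place of the methyl group of compound 2 would give a much lower number, and whether the fluoro step would then stay as small.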